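The source may hold more compounds than are shown below. What is called first, only, known or untested is meant among the compounds shown, and "the series" means these compounds.

Measured so far:
compound 1 `COC(=O)c1cc(CNc2cc(OC)c(OC)c(OC)c2)ccc1OC`: 38100 nM
compound 2 `COc1ccc(CN(C(C)=O)c2cc(OC)c(OC)c(OC)c2)cc1O`: 270 nM
compound 3 `COc1ccc(N(Cc2cc(OC)c(OC)c(OC)c2)C(=O)CN=[N+]=[N-])cc1O`: 38800 nM

In a functional assay on HCT-116 cells (Homo sapiens) for inhibition, read by MTT assay, with a stated time of 48 h (on this read-out higher numbers stand for weaker inhibition and lower numbers for stronger inhibition), compound 2 gives the lowest number of the three; compound 1 and compound 3 each stand well beyond the scatter from it. Within the data shown here, no pair of measured compounds differs in only one place, so no single step has been measured. Compound 4 `COc1ccc(CN(C(=O)C(C)Br)c2cc(OC)c(OC)c(OC)c2)cc1O` is not yet measured. It differs from compound 2 as follows: 1-bromoethyl in place of methyl on a carbonyl carbon. Among the measured compounds shown here, the change sits on a carbonyl carbon whose other neighbour is the amide-type nitrogen; nothing among the measured compounds shows what this exchange does. In this assay the step is expected to be modest and toward weaker inhibition, possibly no further than the scatter. For compound 4 the estimate is 800 nM, from 200 nM to 4000 nM. This means an expected step of a 3.0-fold higher number from compound 2 to compound 4 (0.47 log units; beyond the scatter).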

Compound 4, half-maximal inhibitory concentration: 140 nM
The estimate for compound 4 lay 5.7-fold (0.76 log units) above the measured number, and the stated range ends above it.
By their numbers in this assay, from the lowest: compounds 4 and 2 (each within the scatter of the next); then compounds 1 and 3 (each within the scatter of the next).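

In this assay the exchange of 1-bromoethyl in place of methyl on a carbonyl carbon gives a 1.9-fold lower number from compound 2 to compound 4 (0.29 log units; within the scatter) and so leaves the number unchanged within the scatter. Among these compounds, this is the first measured step, and it shows that this position accepts 1-bromoethyl with no loss of inhibition on this read-out. Nothing measured on these compounds bears on why the exchange has so little effect. The compounds shown leave open whether the bromine or the added carbon matters here, a question that an ethyl group, a 1-chloroethyl group or a longer chain on the same carbonyl carbon would separate.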